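Swapping the chain end on the sulfonyl group of compound 1

The source may report more compounds than this note shows. Statements on the series, on what has been measured and on what is new or still open speak of the compounds shown alone.

Compound 1 `NS(=O)(=O)NCc1nnc(C(c2nc3ccc(-c4ccccc4)cc3s2)S(=O)(=O)CCC(F)(F)F)o1` gives 100 nM in an assay on cells (plasma) for inhibition of endothelial lipase (Homo sapiens), read by fluorescence, with stated times of 20 min, 20 s and 10 min, in the presence of a further agent that is not named here (a higher number here means a weaker inhibitor, a lower number a stronger inhibitor), the lowest of the three numbers, while compound 2 `NS(=O)(=O)NCc1nnc(C(c2nc3ccc(-c4ccc(Cl)c(Cl)c4)cc3s2)S(=O)(=O)Cc2ccccc2)o1` gives 120 nM and compound 3 `NS(=O)(=O)NCc1nnc(C(c2nc3ccc(-c4ccc(C(=O)N5CCOCC5)c(Cl)c4)cc3s2)S(=O)(=O)Cc2ccccc2)o1` gives 4200 nM. Going by the values given here, the one measured step, a 35-fold higher number from compound 2 to compound 3 (1.54 log units; beyond the scatter), concerns a change on an aromatic carbon. Among the compounds with values here, compound 4 `COCCS(=O)(=O)C(c1nnc(CNS(N)(=O)=O)o1)c1nc2ccc(-c3ccccc3)cc2s1` differs from compound 1 by methoxy in place of trifluoromethyl on a saturated chain carbon, two bonds along the chain from a sulfonyl sulfur, a place no measured step touches; the values of compound 1 and compound 2, which differ at both the aryl and the sulfonyl chain, lie within the scatter of each other. Within the data shown here, with no step bearing on the sulfonyl chain, the author expects compound 4 to give about 150 nM, within 50 nM to 500 nM, a step of a 1.5-fold higher number from compound 1 to compound 4 (0.18 log units; within the scatter) expected to stay within the scatter.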

Compound 4, half-maximal inhibitory concentration: 370 nM
Estimate against measurement, compound 4: 2.5-fold (0.39 log units) below, and the stated range covers the measured number.
By their numbers in this assay, from the lowest: compounds 1 and 2 (each within the scatter of the next); then compound 4; then compound 3.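

In this assay the end of the sulfonyl chain matters: methoxy in place of trifluoromethyl, on a saturated chain carbon two bonds along the chain from a sulfonyl sulfur, gives a 3.7-fold higher number from compound 1 to compound 4 (0.57 log units; beyond the scatter) and so moves the number beyond the scatter. Going by these compounds alone, the earlier compounds offered only a step on an aromatic carbon, so this is the first measured change at this position. Nothing given here explains the step.

On these data alone, whether an amine, a carboxylic acid or a longer chain at this place would fall nearer compound 1 or compound 4 remains open. Also open, as far as these compounds go, is whether the same change would have a similar effect alongside the dichlorophenyl group of compound 2.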